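The compounds below may be only part of what the source reports. "The series", "measured", "known", "first", "only" and "open" are said of these compounds alone.

Measured compounds:
compound 1 `CCc1nc2sccn2c1/C=N/OCc1ccc(Cl)c(Cl)c1`: 2600 nM
compound 2 `Clc1ccc(CO/N=C/c2c(-c3ccc4ccccc4c3)nc3occn23)cc1Cl`: 370 nM
compound 3 `Clc1ccc(-c2nc3occn3c2/C=N/OCc2ccc(Cl)c(Cl)c2)cc1`: 410 nM

Among these three numbers from an assay on HepG2 cells for agonist activity at nuclear receptor subfamily 1 group I member 3 (Homo sapiens), read by a luciferase reporter, with a stated time of 23 h (on this read-out lower numbers stand for an effect already at smaller amounts and higher numbers for an effect only at larger amounts of compound), compound 2 gives the lowest value; compound 3 lies within the scatter of it (a 1.1-fold higher number from compound 2 to compound 3 (0.04 log units; within the scatter)), while compound 1 sits well beyond. Compound 4 `C(=N/OCc1ccccc1)\c1c(-c2ccc3ccccc3c2)nc2occn12` is not yet measured. It differs from compound 2 in one place: phenyl in place of 3,4-dichlorophenyl on a saturated chain carbon bound to an oxygen on an unsaturated carbon. No measured step touches this position; the only step shown, from compound 2 to compound 3, changes a different part of the molecule and is within the scatter, so it does not tell what removing both chlorines here will do. Without a measured guide, the expectation for compound 4 is a somewhat higher number, a 4.1-fold higher number from compound 2 to compound 4 (0.61 log units; beyond the scatter), with wide uncertainty. Compound 4 is estimated at 1500 nM, range 400 nM to 6000 nM.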

Compound 4, half-maximal effective concentration: 840 nM
For compound 4 the middle estimate is 1.8-fold (0.25 log units) above the measured one, and the stated range covers the measured number.
By their numbers in this assay, from the lowest: compounds 2 and 3 (each within the scatter of the next); then compound 4; then compound 1.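

On a saturated chain carbon bound to an oxygen on an unsaturated carbon, replacing 3,4-dichlorophenyl with phenyl gives a modest but real shift in this assay, with a 2.3-fold higher number from compound 2 to compound 4 (0.36 log units; beyond the scatter). Among the compounds shown here, this is the first measured change at this position, and it shows that a compound without the two chlorines still gives a reading in the same range as the others. Nothing available here explains the shift. On these data alone, whether a single chlorine would suffice remains open, as does how this phenyl would read carrying a methoxy group, an amine or a carboxylic acid.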